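Cytotoxicity notes: sulfonyl-to-benzyl change on the piperazine

This account rests on a few compounds, and the source may have more. Where it says the series, first, only, none or still open, it means among the compounds named here.

Measured so far in an ADME assay on L02 cells (Homo sapiens) for cytotoxicity, read by MTT assay, with a stated time of 48 h; on this read-out lower numbers stand for stronger inhibition and higher numbers for weaker inhibition:
compound 1 `CCN(CC)c1ccc2cc(C(=O)c3ccc(N4CCN(C(=O)CN5CCN(S(=O)(=O)c6ccc(C(F)(F)F)cc6)CC5)CC4)cc3)oc2c1` gives 17000 nM
compound 2 `CCN(CC)c1ccc2cc(C(=O)c3ccc(N4CCN(C(=O)CN5CCN(S(=O)(=O)c6ccc(C#N)cc6)CC5)CC4)cc3)oc2c1` gives 44100 nM

Among the measured compounds shown here, compound 2 stands at the highest of the two numbers; its nearest neighbour is compound 1, at a 2.6-fold higher number from compound 1 to compound 2 (0.41 log units; beyond the scatter), the only measured step in the set, and it consists of cyano in place of trifluoromethyl on an aromatic carbon.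

Compound 3 `CCN(CC)c1ccc2cc(C(=O)c3ccc(N4CCN(C(=O)CN5CCN(Cc6ccc(F)c(F)c6)CC5)CC4)cc3)oc2c1` is not yet measured. It differs from compound 2 by 3,4-difluorobenzyl in place of (4-cyanophenyl)sulfonyl on an amine nitrogen in a ring. For the measured compounds named here, the one measured step touches only the substituent on the aryl ring of the sulfonyl group; no measured pair shows what happens when the whole sulfonyl unit is taken off and a benzyl put in its place, so that step gives no direct guide here.

With nothing to anchor a direction, the number for compound 3 is expected near that of compound 2, a step of a 1.5-fold lower number from compound 2 to compound 3 (0.17 log units; within the scatter), within the scatter. The estimate for compound 3 in this assay is 30000 nM, with a range of 8000 nM to 100000 nM.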

Compound 3, half-maximal inhibitory concentration: 10200 nM
The estimate for compound 3 lay 2.9-fold (0.47 log units) above the measured number; measured number inside the range.
By their numbers in this assay, from the lowest: compounds 3 and 1 (each within the scatter of the next); then compound 2.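

In this assay, the amine nitrogen in the ring responds to an exchange of the whole sulfonyl unit and not only to a change on its aryl ring: 3,4-difluorobenzyl in place of (4-cyanophenyl)sulfonyl gives a 4.3-fold lower number from compound 2 to compound 3 (0.64 log units; beyond the scatter) as the step. The benzyl compound 3 gives 10200 nM and the sulfonyl compound 1 gives 17000 nM, two numbers within the scatter of each other, so the benzyl change does not take the series outside the span already covered by the sulfonyl compounds. No supporting data explain the shift.

This single step changes the linking unit and the ring substituents together, so their shares cannot be separated. Going by these compounds, an unsubstituted benzyl, a 4-cyanobenzyl or a (3,4-difluorophenyl)sulfonyl group would be needed to separate them, and a simple acetyl group on the same nitrogen remains open too.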